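Isobutoxy in place of a pyrazolylethoxy side chain

The source may hold more compounds than are shown below. What is called first, only, known or untested is meant among the compounds shown, and "the series" means these compounds.

The measured compounds:
compound 1, `Cc1nn(-c2ncnc3nc[nH]c23)c2c1C(OCC(=O)c1ccc(F)cc1)CC(=O)N2`, 3 nM
compound 2, `Cc1nn(-c2ncnc3nc[nH]c23)c2c1C(NC(=O)Cc1cccs1)CC(=O)N2`, 3 nM
compound 3, `Cc1nn(-c2ncnc3nc[nH]c23)c2c1C(OCCn1cccn1)CC(=O)N2`, 16 nM

In a functional assay on HEK293 cells for agonist activity at G-protein coupled receptor 39 (Homo sapiens), read by scintillation proximity assay and inositol phosphate accumulation, with a stated time of 75 min, in the presence of a further agent that is not named here (a higher number here means that more compound is needed for the effect, a lower number that less compound is needed), compound 3 carries the highest number of the three. The step from compound 1 is a 5.3-fold higher number from compound 1 to compound 3 (0.73 log units; beyond the scatter), and from compound 2 it is a 5.3-fold higher number from compound 2 to compound 3 (0.73 log units; beyond the scatter), so compound 3 needs more material than either of its two neighbours. Compound 4, `Cc1nn(-c2ncnc3nc[nH]c23)c2c1C(OCC(C)C)CC(=O)N2`, is not yet measured. It differs from compound 3 only on the side chain: isopropyl in place of (1H-pyrazol-1-yl)methyl on a saturated chain carbon bound to an oxygen on a saturated carbon.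

Both measured steps concern this same side chain and both end at compound 3, each describing the exchange of one ring-bearing chain for another, and each raising the number by a modest amount. Going by the values given here, no measured step shows the ring being removed altogether, as happens in compound 4, so the direction cannot be read from the pair of compounds alone. The two steps suggest that the side chain does move the number, but within a modest span. Compound 4 is therefore expected to stay near compound 3, with a step of about a 1.9-fold higher number from compound 3 to compound 4 (0.27 log units; within the scatter) in this assay. For compound 4 an estimated value of 30 nM is expected, with a range from 8 nM to 120 nM.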

Compound 4, half-maximal effective concentration: 4 nM
Compound 4: the middle estimate sits 7.5-fold (0.88 log units) above what was measured; the measured number lies below the stated range.
By their numbers in this assay, from the lowest: compounds 1, 2 and 4 (each within the scatter of the next); then compound 3.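

In this assay, taking the pyrazole ring off this side chain costs nothing: the isopropyl end gives (a 4.0-fold lower number from compound 3 to compound 4 (0.60 log units; beyond the scatter)), so at this place on a saturated chain carbon bound to an oxygen, no ring is needed for a low number. The ringless isobutoxy chain also stands level with the ring-bearing chains of the two earlier compounds (a 1.3-fold higher number from compound 1 to compound 4 (0.12 log units; within the scatter); a 1.3-fold higher number from compound 2 to compound 4 (0.12 log units; within the scatter)), which shows that this position accepts quite different groups without a clear change in the number. Nothing measured here explains why the pyrazole chain stands apart from the isobutoxy chain.

Going by these compounds, it remains open whether the branching of the isobutoxy chain matters, as a straight butoxy chain would show. On these data alone, it is equally open how far the chain can be shortened to ethoxy or methoxy, and whether a chain ending in an amine or a carboxylic acid is accepted here.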